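Fluoro in place of hydrogen on compound 2

The compounds below may be only part of what the source reports. "The series", "measured", "known", "first", "only" and "open" are said of these compounds alone.

Measured compounds in an assay on isolated protein for agonist activity at Free fatty acid receptor 1 (Homo sapiens); on this read-out lower numbers stand for an effect already at smaller amounts and higher numbers for an effect only at larger amounts of compound:
compound 1 `CC#CC(CC(=O)O)c1ccc(OCc2ccc3nc(-c4ccc(C(F)(F)F)cc4)cn3c2)cc1` gives 558 nM
compound 2 `CC#CC(CC(=O)O)c1ccc(OCc2ccn3cc(-c4ccccc4)nc3c2)cc1` gives 1260 nM
compound 3 `CC#CC(CC(=O)O)c1ccc(OCc2ccc3nc(-c4ccc(F)cc4)cn3c2)cc1` gives 623 nM

Compound 2 stands at the highest of the three numbers in this assay. Its nearest neighbour is compound 3, which shows a lower number than compound 2, a gap beyond the scatter, and compound 1 lies a little further below, also beyond the scatter. Compound 2 carries a plain phenyl group, while compound 1 and compound 3 carry a substituted phenyl on a different core.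

Compound 4 `CC#CC(CC(=O)O)c1ccc(OCc2ccn3cc(-c4ccccc4F)nc3c2)cc1` has not been measured. It differs from compound 2 by fluoro in place of hydrogen on an aromatic carbon.

Going by the values given here, the only step between measured compounds is a 1.1-fold higher number from compound 1 to compound 3 (0.05 log units; within the scatter), which swaps one substituent for another on the same ring position of a different core; it does not report on adding a fluoro where a hydrogen was, nor on the place ortho to a large group. Nothing in the measured set therefore speaks directly for a shift in either direction in this assay.

On this basis the expected step is a 1.3-fold lower number from compound 2 to compound 4 (0.10 log units; within the scatter), that is, no step beyond the scatter. Compound 4 is estimated at 1000 nM, with a range from 400 nM to 2500 nM.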

Compound 4, half-maximal effective concentration: 705 nM
Compound 4: middle estimate off by 1.4-fold (0.15 log units), on the high side; low and high end bracket the measured number.
By their numbers in this assay, from the lowest: compounds 1, 3, 4 and 2 (each within the scatter of the next, the first and the last beyond it).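

In this assay, going by these compounds alone, the change from phenyl to 2-fluorophenyl gives a 1.8-fold lower number from compound 2 to compound 4 (0.25 log units; within the scatter), the first direct reading of a substituent on the phenyl ring of this core. A fluoro on this aromatic carbon, ortho to a large group, is therefore tolerated on the core of compound 2 without a step beyond the scatter, whereas the earlier step between measured compounds compared only fluoro with trifluoromethyl on a different core. No supporting data bear on why the step has this size.

Still open, as far as these compounds go, is whether a different group at this same place, such as chloro, methoxy or an amine, would give a step beyond the scatter, and whether fluoro reads the same at other places on the phenyl ring. Also open is whether the change from phenyl to 2-fluorophenyl would give a similar step on the core of compound 1, since the compounds shown include no matched pair on that core.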